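Replacing a furan ketone with an isopropyl amide

A few compounds are considered here, and "the series" means these few. Any claim that something is new, unique, unknown or untested is made for them only; others in the source may bear on it.

Two pairs of compounds frame this step. Compound 1 `C[C@@H]1C[C@@H]1C(=O)N1CC2CNCC2C1` and compound 2 `CCC(=O)N1CC2CNCC2C1` share one core, and in an assay on CHO cells for agonist activity at Neuronal acetylcholine receptor; alpha3/beta4 (Homo sapiens), read by FLIPR and calcium flux (a higher number here means that more compound is needed for the effect, a lower number that less compound is needed), compound 1 gives 1400 nM, while compound 2 gives 18000 nM. Among the compounds with values here, the only measured step, a 13-fold higher number from compound 1 to compound 2 (1.11 log units; beyond the scatter), comes from swapping a small ring for a short chain on a carbonyl carbon.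

Compound 3 `O=C(c1ccco1)[C@H]1C[C@@H]2CNC[C@@H](C2)C1` sits on a different core, and in this assay compound 3 gives "not determined" (no result reported), so its standing cannot be placed among the values above. Compound 4 `CC(C)NC(=O)[C@H]1C[C@@H]2CNC[C@@H](C2)C1` is derived from it by a single change: isopropylamino in place of furan-2-yl on a carbonyl carbon. Within the data shown here, no measured step touches this kind of change, since the step from compound 1 to compound 2 alters only the size of a carbon group and never exchanges a ring for an amine. With nothing to lean on but the overall spread of the two measured values, the potency of compound 4 in this assay is expected to be weak, estimated at 6000 nM with a range from 600 nM to 60000 nM.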

Compound 4, half-maximal effective concentration: 27000 nM
For compound 4 the middle estimate is 4.5-fold (0.65 log units) below the measured one; the range from low to high includes it.
By their numbers in this assay, from the lowest: compound 1; then compounds 2 and 4 (each within the scatter of the next).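

In this assay, within the data shown here, compound 3 has no reported result while compound 4 gives 27000 nM so no step between them can be read. As far as these compounds go, whether isopropylamino in place of furan-2-yl raises or lowers the number stays open. Nothing shown here offers an explanation for the value of compound 4.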